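The compounds below may be only part of what the source reports. "The series", "measured", "known", "first", "only" and "open" are said of these compounds alone.

Compounds measured so far:
- compound 1, `N#Cc1ccc(Oc2cccnc2)cc1Oc1ccccc1`, gives 78% in an assay on isolated protein for inhibition of Aromatase (Homo sapiens), read by fluorescence, tested at 1 uM; a higher number here means more inhibition at the concentration tested (going by the name of the read-out), a lower number less inhibition
- compound 2, `CN1CCN(c2cc(Oc3cccnc3)ccc2C#N)CC1`, gives 8% in this assay
- compound 3, `COc1ccc(Oc2cc(Oc3cccnc3)ccc2C#N)cc1`, gives 84% in this assay

Compound 3 holds the highest of the three numbers in this assay, though its nearest neighbour, compound 1, sits within the scatter of it, so the two cannot be ordered; compound 2 lies far below both. Compound 4, `N#Cc1ccc(Oc2cccnc2)cc1Oc1cccnc1`, is not yet measured. It differs from compound 3 in one place: pyridin-3-yl in place of 4-methoxyphenyl on an oxygen on an aromatic ring. Among the compounds with values here, two measured steps bear on this. The step of a number 6 percentage points higher from compound 1 to compound 3 (within the scatter) shows that the methoxy contributes nothing resolvable. The step of a number 70 percentage points lower from compound 1 to compound 2 (beyond the scatter) shows that removing the aryloxy group entirely in favour of 4-methylpiperazin-1-yl costs a great deal. Compound 4 keeps a six-membered aromatic ring on that oxygen, so a step near to none beyond the scatter is expected, perhaps slightly downward. Compound 4 is therefore estimated at 75%, with a range from 55% to 90%, which corresponds to an expected step of a number 9 percentage points lower from compound 3 to compound 4 (within the scatter).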

Compound 4, a percentage reported as inhibition, at one concentration (the size of the read-out at that concentration, not a potency): 81%
The estimate for compound 4 lay 6 percentage points below the measured number; low and high end bracket the measured number.
By their numbers in this assay, from the lowest: compound 2; then compounds 1, 4 and 3 (each within the scatter of the next).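

With pyridin-3-yl on the oxygen on an aromatic ring, the result in this assay is a number 3 percentage points lower from compound 3 to compound 4 (within the scatter) and a number 3 percentage points higher from compound 1 to compound 4 (within the scatter), so a ring with a hetero atom cannot be told apart here from the 4-methoxyphenyl or phenyl ring of carbon only. The (pyridin-3-yl)oxy group in place of 4-methylpiperazin-1-yl gives a number 73 percentage points higher from compound 2 to compound 4 (beyond the scatter), which shows that the large gap to compound 2 does not depend on the ring on that oxygen being carbon only. Nothing available gives a reason for these results.

The compounds shown leave open whether a saturated group such as cyclohexyl on the oxygen would hold the value, and whether a carboxylic acid on the ring would. They also leave open whether an open-chain amine on the aromatic carbon would fall as far as the 4-methylpiperazin-1-yl group.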